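Changing the ether side chain of compound 2

A few compounds are considered here, and "the series" means these few. Any claim that something is new, unique, unknown or untested is made for them only; others in the source may bear on it.

Three compounds have been measured in a functional assay on HEK293 cells for agonist activity at G-protein coupled receptor 39 (Homo sapiens), read by scintillation proximity assay and inositol phosphate accumulation, with a stated time of 75 min, in the presence of a further agent that is not named here; a higher number here means that more compound is needed for the effect, a lower number that less compound is needed:

Compound 1 `Cc1nn(-c2ncnc3nc[nH]c23)c2c1C(OC1CCCC1)CC(=O)N2` gives 2 nM.
Compound 2 `Cc1cc(C)n(CCOC2CC(=O)Nc3c2c(C)nn3-c2ncnc3nc[nH]c23)n1` gives 16 nM.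
Compound 3 `Cc1nn(-c2ncnc3nc[nH]c23)c2c1C(c1ccc(F)cc1Cl)CC(=O)N2` gives 9 nM.

Compound 2 has the highest number of the three. Against compound 3 it lies within the scatter, a 1.8-fold lower number from compound 2 to compound 3 (0.25 log units; within the scatter), while against compound 1 the gap is real, an 8.0-fold higher number from compound 1 to compound 2 (0.90 log units; beyond the scatter). Compound 4 `Cc1nn(-c2ncnc3nc[nH]c23)c2c1C(OCc1cc(F)cc3c1OCOC3)CC(=O)N2` differs from compound 2 at a single position: a group of 11 heavy atoms (8 carbon, 2 oxygen, 1 fluorine; one six-membered non-aromatic ring with 2 hetero atoms, one six-membered aromatic ring of carbon only) in place of a group of 8 heavy atoms (6 carbon, 2 nitrogen; one five-membered aromatic ring with 2 hetero atoms), on a saturated chain carbon bound to an oxygen on a saturated carbon. Among the measured compounds shown here, no measured step shows this exact change. The step from compound 1 to compound 2 shows that this position matters and that the ether group of compound 2 is not the most favourable one, so a modest move toward compound 1 is expected. Compound 4 is therefore expected to give 6 nM. The expected range for compound 4 runs from 2 nM to 20 nM. The expected step is a 2.7-fold lower number from compound 2 to compound 4 (0.43 log units; beyond the scatter).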

Compound 4, half-maximal effective concentration: 1.5 nM
Estimate against measurement, compound 4: 4.0-fold (0.60 log units) above; measured number below the stated range.
By their numbers in this assay, from the lowest: compounds 4 and 1 (each within the scatter of the next); then compounds 3 and 2 (each within the scatter of the next).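

Swapping the (3,5-dimethyl-1H-pyrazol-1-yl)methyl group for the two-ring, fluorine-bearing group gives an 11-fold lower number from compound 2 to compound 4 (1.03 log units; beyond the scatter), so this ether position accepts a group of 11 heavy atoms with no penalty. Compound 4 at 1.5 nM and compound 1 at 2 nM lie within the scatter of each other, showing that a cyclopentyl group and this much larger group can serve equally well here. Nothing measured here explains the size of this step.

The compounds shown do not separate the contribution of the fluorine from that of either ring. On these data alone, how an amine or a carboxylic acid on this ether chain would behave also remains open.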